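A few compounds are considered here, and "the series" means these few. Any claim that something is new, unique, unknown or untested is made for them only; others in the source may bear on it.

Working notes on the series, read in a functional assay on NCI/ADR-RES cells (Homo sapiens) for inhibition, read by sulforhodamine B assay, with a stated time of 48 h (a higher number here means a weaker inhibitor of growth, a lower number a stronger inhibitor of growth), as concentration for half-maximal growth inhibition. Compound 1 (`S=C(N/N=C/c1cccs1)Nc1ccccc1`) gives > 100000 nM as a limit of the assay, not a number. Compound 2 (`S=C(N/N=C/c1cccs1)Nc1cccnc1`) gives > 100000 nM as a limit too. Compound 1 therefore has no number of its own and stands at the limit of > 100000 nM in this assay, at which 2 of the 3 values shown sit, in this set. Compound 3 (`S=C(N/N=C/c1cccs1)Nc1cccc2ccccc12`) is the only one so far to give a number, at 6600 nM in this assay with its aromatic part changed well beyond a single small group.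

Compound 4 (`COc1ccc(NC(=S)N/N=C/c2cccs2)cc1`) keeps the core of compound 1 and carries methoxy in place of hydrogen on an aromatic carbon of the six-membered aromatic ring of carbon only, para to a large group (methoxy in place of hydrogen on an aromatic carbon). Among the compounds with values here, no measured pair isolates a change of this kind, so the expectation is tentative. Compound 3 at 6600 nM shows that a number can be reached, but its change from compound 1 is much larger than this one. A small shift toward stronger growth inhibition is therefore expected, and a second limit result is about as likely as a number. The estimated step is an at least 2.0-fold lower number from compound 1 to compound 4 (0.30 log units; that floor lies within the scatter) and remains uncertain. For compound 4 the estimate is 50000 nM with an expected range from 12000 nM to 100000 nM in this assay when a number is reported.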

Compound 4, concentration for 50% growth inhibition: > 100000 nM
Compound 4 ended at the assay's limit (the forecaster's own chance of this, stated with the estimate: 55%); at least 2.0-fold (0.30 log units) between middle value and limit.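

No step can be read between compound 1 and compound 4, since both sit at the same limit of the assay, which is not a number: the limit of > 100000 nM in this assay, at which 3 of the 4 values shown sit.

The compounds shown leave open whether methoxy in place of hydrogen on an aromatic carbon changes growth inhibition in this assay at all.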